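A few compounds are considered here, and "the series" means these few. Any claim that something is new, unique, unknown or untested is made for them only; others in the source may bear on it.

Measured so far in a functional assay on UACC-62 cells (Homo sapiens) for inhibition, read by sulforhodamine B assay, with a stated time of 48 h; on this read-out higher numbers stand for weaker inhibition of growth and lower numbers for stronger inhibition of growth:
Compound 1 `COc1cc(-c2cc(/C=C/C(=O)c3ccc(N)cc3)[nH]n2)cc(OC)c1OC` gives 3580 nM.
Compound 2 `COc1cc(-c2cc(/C=C/C(=O)c3ccc(Cl)c(Cl)c3)[nH]n2)cc(OC)c1OC` reaches only a limit of this assay, > 100000 nM.
Compound 3 `COc1ccc(C(=O)/C=C/c2cc(-c3cc(OC)c(OC)c(OC)c3)n[nH]2)cc1` gives 3650 nM.

Compound 3 and compound 1 form a pair within the scatter (a 1.0-fold higher number from compound 1 to compound 3 (0.01 log units; within the scatter)), so the two numbers are not separated. Compound 4 `COc1cc(-c2cc(/C=C/C(=O)c3ccc(F)c(F)c3)[nH]n2)cc(OC)c1OC` differs from compound 3 by 3,4-difluorophenyl in place of 4-methoxyphenyl on a carbonyl carbon. Among the compounds with values here, two measured steps bear on this change: an at least 27-fold lower number from compound 2 to compound 3 (1.43 log units; beyond the scatter) and an at least 27-fold higher number from compound 1 to compound 2 (1.44 log units; beyond the scatter), both large, both placing the 3,4-dichlorophenyl compound at the limit. Compound 4 carries the closely related 3,4-difluorophenyl, so a large step toward weaker inhibition is expected, an 8.2-fold higher number from compound 3 to compound 4 (0.91 log units; beyond the scatter). The estimate for compound 4 is 30000 nM, between 6000 nM and 150000 nM, with a fair chance that this assay again reports only a limit.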

Compound 4, concentration for total growth inhibition: 7440 nM
Estimate against measurement, compound 4: 4.0-fold (0.61 log units) above; the measured number falls inside the stated range.
By their numbers in this assay, from the lowest: compounds 1 and 3 (each within the scatter of the next); then compound 4. At a limit, above all of these: compound 2.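

The position on the carbonyl carbon separates the two dihalophenyl groups in this assay, since 3,4-difluorophenyl gives a measurable number where 3,4-dichlorophenyl does not: an at least 13-fold lower number from compound 2 to compound 4 (1.12 log units; beyond the scatter). Compound 2 stands at a limit, so that step is only a bound: the limit of > 100000 nM in this assay, at which 1 of the 4 values shown sits. Against the 4-methoxyphenyl and 4-aminophenyl compounds the change is modest, with a 2.0-fold higher number from compound 3 to compound 4 (0.31 log units; beyond the scatter) and a 2.1-fold higher number from compound 1 to compound 4 (0.32 log units; beyond the scatter), so the large loss seen with compound 2 does not carry over to compound 4.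

Open, from the compounds shown here alone, is how a single fluorine, a trifluoromethyl or a nitrile on this phenyl would read, and whether a carboxylic acid there would keep growth inhibition.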